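The source may hold more compounds than are shown below. What is called first, only, known or untested is meant among the compounds shown, and "the series" means these compounds.

Measured so far in a functional assay on KB cells (Homo sapiens) for cytotoxicity, read by sulforhodamine B assay; on this read-out higher numbers stand for weaker inhibition and lower numbers for stronger inhibition:
- compound 1, `C=C1[C@@H](C/C=C2/C(=O)OC[C@H]2OC(C)=O)[C@]2(C)CC[C@@H](OC(C)=O)[C@@](C)(CO[Si](C)(C)C(C)(C)C)[C@H]2C[C@@H]1O`: 9790 nM
- compound 2, `C=C1[C@@H](OC(C)=O)C[C@@H]2[C@](C)(COC=O)[C@H](OC(C)=O)CC[C@@]2(C)[C@@H]1C[C@@H](Nc1ccc(Br)cc1)C1=CCOC1=O`: 24000 nM
- compound 3, `C=C1[C@@H](OC(C)=O)C[C@@H]2[C@](C)(CO[Si](C)(C)C(C)(C)C)[C@H](OC(C)=O)CC[C@@]2(C)[C@@H]1C[C@@H](Nc1cccc(F)c1)C1=CCOC1=O`: 4560 nM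

Among these three, compound 2 stands at the highest number, meaning the weakest inhibition of the set. Its nearest neighbour is compound 1, whose number is lower by a margin that lies beyond the usual scatter, and compound 3 sits further still below it, also beyond the scatter. Compound 2 and compound 3 share the same core and the same side chain bearing a substituted anilino group, but they differ in more than one place at once, so nothing about any single change can be read from that pair.

The step of interest goes from compound 2 to compound 4, `C=C1[C@@H](OC(C)=O)C[C@@H]2[C@](C)(COC=O)[C@H](OC(C)=O)CC[C@@]2(C)[C@@H]1C[C@@H](Nc1ccccc1)C1=CCOC1=O`, which has not yet been measured. The change is a single small one: hydrogen in place of bromo on an aromatic carbon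

Going by the values given here, with no measured pair isolating this change, the expected step is small, with no clear direction and likely within the scatter. For compound 4 the estimated value in this assay is 20000 nM, with a range from 8000 nM to 50000 nM, corresponding to an expected step of a 1.2-fold lower number from compound 2 to compound 4 (0.08 log units; within the scatter).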

Compound 4, half-maximal inhibitory concentration: 32100 nM
Estimate against measurement, compound 4: 1.6-fold (0.21 log units) below; low and high end bracket the measured number.
By their numbers in this assay, from the lowest: compound 3; then compound 1; then compounds 2 and 4 (each within the scatter of the next).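

In this assay, going by these compounds alone, compounds 2 and 4 form the first pair that differs in only one place, and the exchange of bromo for hydrogen gives a 1.3-fold higher number from compound 2 to compound 4 (0.13 log units; within the scatter). On this evidence, the 4-bromophenyl group and the plain phenyl group cannot be told apart in this read-out, so losing this one bromine atom from the aromatic carbon para to a large group leaves no measurable mark on the cytotoxicity of this particular compound pair. Nothing available accounts for the size of this step, so the result stands as an observation without an explanation.

A single exchange cannot show whether this place tolerates every group, and a methoxy group, an amine or a carboxylic acid on the same aromatic carbon could still give a step beyond the scatter. As far as these compounds go, it also remains open whether bromo and hydrogen would again read alike on a compound that carries a different group elsewhere on the shared core, such as the silyl ether found in compound 3.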